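Triazolyl replaces carboxyphenyl on the shared core

This account rests on a few compounds, and the source may have more. Where it says the series, first, only, none or still open, it means among the compounds named here.

Measured compounds in an in vitro assay on CHO cells for displacement of a labelled ligand from Bombesin receptor subtype-3 (Homo sapiens), read by scintillation counting, with a stated time of 2 h; a lower number here means a stronger inhibitor, a higher number a weaker inhibitor:
compound 1 `CCC(C)(C)Cc1c[nH]c(CCc2ccc(-c3cnccn3)cc2)n1` gives 51 nM
compound 2 `CCC(C)(C)Cc1c[nH]c(CCc2ccc(-c3ccccc3C(=O)O)cc2)n1` gives 11 nM
compound 3 `c1ccc(-c2ccc(CCc3nc(CC4CCCC4)c[nH]3)cc2)nc1` gives 177 nM

Compound 2 stands lowest of the three numbers. Its nearest neighbour is compound 1, the step from compound 1 to compound 2 being a 4.6-fold lower number from compound 1 to compound 2 (0.67 log units; beyond the scatter). For the measured compounds named here, compound 3, which differs from compound 2 in two places, shows the highest number of the set, and the two values sit well apart; no single-change step joins them.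

Compound 4, `CCC(C)(C)Cc1c[nH]c(CCc2ccc(-n3cncn3)cc2)n1`, differs from compound 2 in one place: 1H-1,2,4-triazol-1-yl in place of 2-carboxyphenyl on an aromatic carbon. Going by the values given here, the one measured step that bears on this is the exchange of a small nitrogen-containing aromatic ring for the 2-carboxyphenyl group, which gave a 4.6-fold lower number from compound 1 to compound 2 (0.67 log units; beyond the scatter). Among the compounds with values here, compound 4 reverses that direction, exchanging the 2-carboxyphenyl for a smaller aromatic ring with three hetero atoms and no hydrogen-bond donor, so a higher number than compound 2 is expected, of a size comparable to that earlier step, though the new ring is not the one in compound 1.

Compound 4 is therefore expected to give 60 nM, within 25 nM to 150 nM. The expected step is a 5.5-fold higher number from compound 2 to compound 4 (0.74 log units; beyond the scatter).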

Compound 4, half-maximal inhibitory concentration: 340 nM
Estimate against measurement, compound 4: 5.7-fold (0.75 log units) below; the whole stated range lies below it.
By their numbers in this assay, from the lowest: compound 2; then compound 1; then compounds 3 and 4 (each within the scatter of the next).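

In this assay, the substituent on this aromatic carbon, para to a large group, governs the number strongly: the change gives a 31-fold higher number from compound 2 to compound 4 (1.49 log units; beyond the scatter), a larger move than a 4.6-fold lower number from compound 1 to compound 2 (0.67 log units; beyond the scatter) suggested. The small nitrogen-containing aromatic rings are also not interchangeable here, since 1H-1,2,4-triazol-1-yl in place of pyrazin-2-yl gives a 6.7-fold higher number from compound 1 to compound 4 (0.82 log units; beyond the scatter), so the identity of the entering ring matters as well as the departure of 2-carboxyphenyl. No supporting data are available to explain either step.

As far as these compounds go, it remains open whether the low number of compound 2 depends on the carboxylic acid or on the phenyl ring that carries it. Plain phenyl, or a primary amide in place of the carboxylic acid, at this position on the shared core would separate the two.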